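Piperidin-1-yl in place of the bicyclic group on the carbonyl

The source may report more compounds than this note shows. Statements on the series, on what has been measured and on what is new or still open speak of the compounds shown alone.

Values so far in an assay on HEK293 cells for positive allosteric modulation of metabotropic glutamate receptor 5 (Homo sapiens), read by FLIPR; on this read-out higher numbers stand for an effect only at larger amounts of compound and lower numbers for an effect already at smaller amounts:
compound 1 `O=C(C1CCC(F)(F)CC1)N1CC(c2nc(-c3cccc(Cl)c3)no2)C1`: 180 nM
compound 2 `COC1CCCN(C(=O)N2CC(c3nc(-c4cccc(Cl)c4)no3)C2)C1`: > 10000 nM
compound 3 `O=C([C@H]1CC2CCC1C2)N1CC(c2nc(-c3cccc(Cl)c3)no2)C1`: 74 nM

Compound 3 has the lowest of the two numbers; compound 1 stands next, separated by the step of a 2.4-fold lower number from compound 1 to compound 3 (0.39 log units; beyond the scatter). For compound 2 the value is a limit of this assay, not a number (the limit of > 10000 nM in this assay, at which 1 of the 3 values shown sits).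

Compound 4 `O=C(N1CCCCC1)N1CC(c2nc(-c3cccc(Cl)c3)no2)C1` is the next candidate for this assay. It differs from compound 3 by a group of 6 heavy atoms (5 carbon, 1 nitrogen; one six-membered non-aromatic ring with 1 hetero atom) in place of a group of 7 heavy atoms (7 carbon; 2 five-membered non-aromatic rings of carbon only), on a carbonyl carbon.

Going by the values given here, two measured steps bear on this change, both involving a six-membered non-aromatic ring with 1 hetero atom on the carbonyl carbon: an at least 55-fold higher number from compound 1 to compound 2 (1.74 log units; beyond the scatter) and an at least 130-fold lower number from compound 2 to compound 3 (2.13 log units; beyond the scatter). Both are large and both point the same way, the ring with the hetero atom on the carbonyl giving only a limit. Compound 4 carries piperidin-1-yl without the methoxy group of compound 2, so whether the outcome differs from compound 2 is open; the shown steps argue for a large rise in number from compound 3, with a fair chance of another limit.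

On that basis compound 4 is expected to give about 8000 nM in this assay, within 1500 nM to 40000 nM, corresponding to an expected step of a 110-fold higher number from compound 3 to compound 4 (2.03 log units; beyond the scatter).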

Compound 4, half-maximal effective concentration: 370 nM
Compound 4: the middle estimate sits 22-fold (1.33 log units) above what was measured; measured number below the stated range.
By their numbers in this assay, from the lowest: compound 3; then compound 1; then compound 4. At a limit, above all of these: compound 2.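

A ring nitrogen on the carbonyl carbon does not by itself end the response in this assay: piperidin-1-yl gives a measurable value, with a 5.0-fold higher number from compound 3 to compound 4 (0.70 log units; beyond the scatter) and a 2.1-fold higher number from compound 1 to compound 4 (0.31 log units; beyond the scatter), so the two groups of carbon only keep the lower numbers, but by modest steps. The large loss seen earlier goes instead with the methoxy group on a saturated ring carbon, since taking it away and leaving hydrogen gives an at least 27-fold lower number from compound 2 to compound 4 (1.43 log units; beyond the scatter), a large step from a change in one place. The value of compound 2 is a limit of the assay and not a number, so the true size of that step stays unknown: the limit of > 10000 nM in this assay, at which 1 of the 4 values shown sits.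

Still open, going by these compounds, is whether the loss belongs to the methoxy group as such or would also follow from a hydroxy, fluoro or methyl group on the same piperidine ring. Also open, on these data alone, is how morpholin-4-yl, pyrrolidin-1-yl or an open-chain dimethylamino group on the carbonyl carbon would read in this assay, and so how far the nitrogen-linked groups can close the gap to the bicyclic group of compound 3.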